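Pyrazine hydrazone series: cytotoxicity notes on compound 4

The source may hold more compounds than are shown below. What is called first, only, known or untested is meant among the compounds shown, and "the series" means these compounds.

Measured compounds:
- compound 1, `O=C(N/N=C/c1cccc(Cl)c1)c1cnccn1`: 100%
- compound 2, `O=C(N/N=C/c1ccc(F)cc1)c1cnccn1`: 69%
- compound 3, `COc1ccccc1/C=N/NC(=O)c1cnccn1`: 100%

In an ADME assay on J774 cells (Mus musculus) for cytotoxicity, read by MTT assay, with a stated time of 48 h, tested at 100 ug/mL (on this read-out lower numbers stand for a stronger effect and higher numbers for a weaker effect at the one concentration tested), compound 2 gives 69%, the lowest of the three numbers, and its gap to compound 1 and to compound 3 lies beyond the scatter; compound 1 and compound 3 give numbers that sit within the scatter of each other. Compound 4, `N#Cc1ccc(/C=N/NC(=O)c2cnccn2)cc1`, has not been measured. It differs from compound 2 by cyano in place of fluoro on an aromatic carbon, on an aromatic carbon of a six-membered aromatic ring of carbon only, para to a large group. Within the data shown here, no measured pair shows this change, so its size is open. With two of three compounds showing no effect, compound 4 is expected to move upward toward a weaker effect, by a number 16 percentage points higher from compound 2 to compound 4 (beyond the scatter). Compound 4 is thus estimated at 85%, within 60% to 100%.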

Compound 4, a percentage reported as activity, at one concentration (the size of the read-out at that concentration, not a potency): 100%
Compound 4: middle estimate off by 15 percentage points, on the low side; measured number inside the range.
By their numbers in this assay, from the lowest: compound 2; then compounds 1, 3 and 4 (each within the scatter of the next).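

In this assay, among these compounds, the swap of cyano in place of fluoro on an aromatic carbon, para to a large group, gives a large step, a number 31 percentage points higher from compound 2 to compound 4 (beyond the scatter), the first reading of any single change at this position. Among the compounds shown here, the shared core therefore does not by itself fix the number here, since compound 4 gives 100% with only this one group changed. No measurement at hand gives a cause for this step.

Open, on these data alone, is whether an amine, a carboxylic acid or a methoxy group at this same place would stay with compound 2 or with compound 4. Also open, as far as these compounds go, is whether fluoro keeps its number on other ring carbons.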